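Swapping Iodo for Trifluoromethyl on a Shared Core

The source may hold more compounds than are shown below. What is called first, only, known or untested is meant among the compounds shown, and "the series" means these compounds.

Compound 1 `COc1ccc(Cn2c(=O)nc(NCCNC(=N)N)n(Cc3ccc(I)cc3)c2=O)cc1` was tested in a functional assay on the whole organism (strain C57Bl/6) for inhibition, with Mus musculus as the target, with a stated time of 180 min, at 48 degrees C (on this read-out higher numbers stand for an effect only at larger amounts of compound and lower numbers for an effect already at smaller amounts), where compound 1 gives 0.039 nM. Among the three measured compounds this is the second highest number. Compound 2 `COc1ccc(Cn2c(NCCNC(=N)N)nc(=O)n(Cc3ccc([N+](=O)[O-])cc3)c2=O)cc1` gives 0.048 nM, a value within the scatter of compound 1, while compound 3 `COc1ccc(Cn2c(NCCNC(=N)N)nc(=O)n(Cc3ccc(C)cc3)c2=O)cc1` gives 0.0044 nM, a value that lies well beyond the scatter below both.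

Compound 4 `COc1ccc(Cn2c(=O)nc(NCCNC(=N)N)n(Cc3ccc(C(F)(F)F)cc3)c2=O)cc1` differs from compound 1 in one place: trifluoromethyl in place of iodo on an aromatic carbon. Within the data shown here, the only measured step that exchanges a group on that same aromatic carbon is an 11-fold lower number from compound 2 to compound 3 (1.04 log units; beyond the scatter), which shows that a single exchange there can move the number strongly. Among the measured compounds shown here, no measured step swaps iodo for trifluoromethyl, so the direction for compound 4 remains open. The values of compound 1 and compound 2 show that iodo and nitro give numbers within the scatter of each other, so an exchange at this place need not move the number at all. For compound 4 the expected step of a 1.0-fold higher number from compound 1 to compound 4 (0.01 log units; within the scatter) is therefore estimated to stay within the scatter or only a little beyond it, with a wide range to allow for either direction. In this assay compound 4 is expected to give about 0.04 nM, in a range from 0.012 nM to 0.15 nM.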

Compound 4, half-maximal effective concentration: 0.048 nM
The estimate for compound 4 lay 1.2-fold (0.08 log units) below the measured number; the range from low to high includes it.
By their numbers in this assay, from the lowest: compound 3; then compounds 1, 2 and 4 (each within the scatter of the next).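

In this assay, replacing iodo with trifluoromethyl on this aromatic carbon gives a 1.2-fold higher number from compound 1 to compound 4 (0.09 log units; within the scatter), so the count of heavy atoms in the group rises from 1 to 4 with no change beyond the scatter. Iodo, nitro and trifluoromethyl now give numbers within the scatter of one another when they sit at this place on the shared core, which makes three groups that cannot be told apart in this assay. Among these compounds, that makes methyl the only group here that stands apart: compound 3 gives 0.0044 nM and the step of an 11-fold lower number from compound 2 to compound 3 (1.04 log units; beyond the scatter) is large, so this position does not respond to every exchange in the same way.

No measurement offered here explains why these three groups match or why methyl differs. From the compounds shown here alone, it also remains open whether an amine, a carboxylic acid or a longer chain such as ethyl at this carbon would give a number like that of compound 3 or like those of compound 1 and compound 4, and so whether methyl is a lone case.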